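The source may report more compounds than this note shows. Statements on the series, on what has been measured and on what is new or still open speak of the compounds shown alone.

Compounds measured:
compound 1 `CC(O)(C(=O)Nc1ccc(S(=O)(=O)c2ccc(F)cc2)cc1)C(F)(F)F`: 8600 nM
compound 2 `CC(O)(C(=O)Nc1ccc(S(=O)(=O)c2cccc(Cl)c2)cc1)C(F)(F)F`: 10000 nM
compound 3 `CC(O)(C(=O)Nc1ccc(S(=O)(=O)c2cccc(C(F)(F)F)c2)cc1)C(F)(F)F`: > 30000 nM, a limit only, not a number

In a functional assay (Cavia porcellus) with sulfonylurea receptors; K-ATP channels (Homo sapiens) as the target (a higher number here means a weaker inhibitor, a lower number a stronger inhibitor), compound 2 stands highest of the two numbers given, with compound 1 nearest, and the step of a 1.2-fold higher number from compound 1 to compound 2 (0.07 log units; within the scatter) lies within the scatter. The step of an at least 3.0-fold higher number from compound 2 to compound 3 (0.47 log units; beyond the scatter) runs into (the limit of > 30000 nM in this assay, at which 1 of the 3 values shown sits). Compound 4 `CC(O)(C(=O)Nc1ccc(S(=O)(=O)c2nccs2)cc1)C(F)(F)F` differs from compound 2 by 1,3-thiazol-2-yl in place of 3-chlorophenyl on a sulfonyl sulfur. For the measured compounds named here, no measured step exchanges the ring on the sulfonyl sulfur for one with hetero atoms, so the two steps offer only a loose guide: one shows no change, the other a loss to the limit. A step in either direction, or none beyond the scatter, is expected. Compound 4 is estimated at 12000 nM, between 4000 nM and 40000 nM. The expected step is a 1.2-fold higher number from compound 2 to compound 4 (0.08 log units; within the scatter).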

Compound 4, half-maximal inhibitory concentration: 1400 nM
Beside the measured number, compound 4's estimate is 8.6-fold (0.93 log units) above it; measured number below the stated range.
By their numbers in this assay, from the lowest: compound 4; then compounds 1 and 2 (each within the scatter of the next). At a limit, above all of these: compound 3.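

In this assay, the ring on the sulfonyl sulfur can also give a stronger inhibitor, not only an unchanged or weaker one: a 7.1-fold lower number from compound 2 to compound 4 (0.85 log units; beyond the scatter). The same holds against the other measured phenyl ring: a 6.1-fold lower number from compound 1 to compound 4 (0.79 log units; beyond the scatter). Among the compounds shown, 1,3-thiazol-2-yl is the only ring at this place with hetero atoms, so this gain rests on compound 4 alone.

Nothing at hand accounts for the gain. Going by these compounds, it remains open whether a pyridin-2-yl or 1,3-oxazol-2-yl ring on the sulfonyl sulfur would give a similar number.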